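A Longer Methylamide Chain in Place of Hydroxycarbamoyl

The compounds below may be only part of what the source reports. "The series", "measured", "known", "first", "only" and "open" are said of these compounds alone.

Measured in a functional assay on Bel-7402 cells (Homo sapiens) for inhibition, read by MTT assay, with a stated time of 72 h; on this read-out higher numbers stand for weaker inhibition and lower numbers for stronger inhibition:
- compound 1 `Nc1ncnc2c1c(-c1cnc3[nH]ccc3c1)nn2CCCCCCCCC(=O)NO`: 18900 nM
- compound 2 `Nc1ncnc2c1c(-c1cnc3[nH]ccc3c1)nn2CCCCCCCCCC(=O)NO`: 42100 nM
- compound 3 `Nc1nc2cc(-c3nn(CCCCC(=O)NO)c4ncnc(N)c34)ccc2o1`: 2400 nM

Of these three, compound 3 has the lowest number and so shows the strongest inhibition in this assay. The next step leads to compound 4 `CNC(=O)CCCCCCCn1nc(-c2ccc3oc(N)nc3c2)c2c(N)ncnc21`, where the change is 3-(methylcarbamoyl)propyl in place of hydroxycarbamoyl on a saturated chain carbon, four bonds along the chain from an aromatic nitrogen. Among the measured compounds shown here, the data hold no measured step that removes hydroxycarbamoyl, so that part of the change has no direct guide. For the measured compounds named here, the only measured step, a 2.2-fold higher number from compound 1 to compound 2 (0.35 log units; beyond the scatter), replaces hydroxycarbamoyl with (hydroxycarbamoyl)methyl, and it is modest. It also comes from a different core, so it bears only loosely on the present change. It suggests a somewhat higher number, and the loss of hydroxycarbamoyl leaves the size of the step uncertain. A moderate move toward weaker inhibition is therefore expected, estimated as a 3.8-fold higher number from compound 3 to compound 4 (0.57 log units; beyond the scatter). For compound 4 the estimated value is 9000 nM, with an expected range of 2500 nM to 40000 nM.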

Compound 4, half-maximal inhibitory concentration: 13200 nM
Beside the measured number, compound 4's estimate is 1.5-fold (0.17 log units) below it; low and high end bracket the measured number.
By their numbers in this assay, from the lowest: compound 3; then compounds 4 and 1 (each within the scatter of the next); then compound 2.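

In this assay the swap of hydroxycarbamoyl for 3-(methylcarbamoyl)propyl gives a modest loss of inhibition (a 5.5-fold higher number from compound 3 to compound 4 (0.74 log units; beyond the scatter)). The earlier step, from compound 1 to compound 2, kept hydroxycarbamoyl within the group, whereas this one removes it, and it shows that on the core of compound 3 a methylcarbamoyl group in its place still gives a measurable value in this assay. Nothing shown here gives a measured reason for the size of this step.

The change alters the chain and the terminal group at once, so these compounds cannot tell which of the two carries the step. Going by these compounds, it also stays open how this core would respond to hydroxycarbamoyl on the longer chain of compound 4, or to a carboxylic acid or a primary amide in its place.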